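The compounds below may be only part of what the source reports. "The series", "measured", "known", "first", "only" and "open" are said of these compounds alone.

In a functional assay on HCT-116 cells (Homo sapiens) for inhibition, read by sulforhodamine B assay, with a stated time of 72 h (a lower number here means a stronger inhibitor, a higher number a weaker inhibitor), compound 3 `CC(c1ccc(-c2ccccc2)c(F)c1)c1nnc2n1N=C(c1ccc(Cl)cc1Cl)CS2` gives 6900 nM, the highest of the three numbers measured, although its distances to compound 2 `CC(C)Cc1ccc(C(C)c2nnc3n2N=C(c2ccc(Cl)cc2)CS3)cc1` at 6700 nM and to compound 1 `Cc1ccc(C2=Nn3c(nnc3C(C)c3ccc(CC(C)C)cc3)SC2)cc1` at 4000 nM both stay within the scatter. Compound 4 `CC(c1ccc(-c2ccccc2)c(F)c1)c1nnc2n1N=C(c1ccc(Cl)cc1)CS2` differs from compound 3 by hydrogen in place of chloro on an aromatic carbon; cut one bond further out, the change reads 2,4-dichlorophenyl to 4-chlorophenyl. Going by the values given here, the only measured step on a ring of this kind, a 1.7-fold higher number from compound 1 to compound 2 (0.22 log units; within the scatter), concerned a different swap and stayed within the scatter, and no measured pair removes a chloro group. The expectation in this assay is therefore no step beyond the scatter, namely a 1.2-fold lower number from compound 3 to compound 4 (0.06 log units; within the scatter). Compound 4 is estimated at 6000 nM, between 2500 nM and 14000 nM.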

Compound 4, half-maximal inhibitory concentration: 7800 nM
Beside the measured number, compound 4's estimate is 1.3-fold (0.11 log units) below it, and the stated range covers the measured number.
By their numbers in this assay, from the lowest: compounds 1, 2, 3 and 4 (each within the scatter of the next).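

In this assay, going by these compounds alone, the change from 2,4-dichlorophenyl to 4-chlorophenyl gives a 1.1-fold higher number from compound 3 to compound 4 (0.05 log units; within the scatter) and is the first measured pair to remove a chloro group. At this place, ortho to a large group and meta to a chloro group, hydrogen and chloro therefore cannot be told apart in this assay. Nothing available offers an explanation for this result.

The compounds shown leave open whether a methoxy group or an amine at this place would give a step beyond the scatter. On these data alone, whether removing the remaining chloro group would do so also stays open.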